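Swapping tert-butyl for phenyl on a carbonyl carbon

A few compounds are considered here, and "the series" means these few. Any claim that something is new, unique, unknown or untested is made for them only; others in the source may bear on it.

Compound 1 `CO[C@H]1C(=O)N2C(C(=O)C(C)(C)C)=C(C)[C@@H](OC(=O)C(C)(C)C)S(=O)(=O)C12` was tested in a physicochemical assay, at pH 7.4 (on this read-out higher numbers stand for a longer-lived compound and lower numbers for a shorter-lived compound), and compound 1 gives 54 h. Compound 2 `CO[C@H]1C(=O)N2C(C(=O)C(C)(C)C)=C(C)[C@@H](OC(=O)c3ccccc3)S(=O)(=O)C12` differs from it by one change: phenyl in place of tert-butyl on a carbonyl carbon. In this assay compound 2 gives 24 h, a step of a 2.3-fold lower number from compound 1 to compound 2 (0.35 log units; beyond the scatter).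

Compound 3 `CO[C@H]1C(=O)N2C(C(=O)C(C)(C)C)=C(CSc3nnnn3C)[C@@H](Sc3nnnn3C)S(=O)(=O)C12` is built on a different core; the difference between the two cores is not broken down here. In this assay compound 3 gives 31 h.

Compound 4 `CO[C@H]1C(=O)N2C(C(=O)c3ccccc3)=C(CSc3nnnn3C)[C@@H](Sc3nnnn3C)S(=O)(=O)C12` has not yet been measured. It carries the same kind of change as the earlier pair: phenyl in place of tert-butyl on a carbonyl carbon. The surroundings are not identical, though. In compound 2 the carbonyl carbon sits on an oxygen next to a carbonyl group, whereas in compound 4 it sits on a double-bonded ring carbon, so the step may not carry over exactly.

Resting on the one earlier example, where compound 1 to compound 2 gave a 2.3-fold lower number from compound 1 to compound 2 (0.35 log units; beyond the scatter), the step from compound 3 to compound 4 in this assay is expected to be a 2.1-fold lower number from compound 3 to compound 4 (0.32 log units; beyond the scatter). Compound 4 is therefore estimated at 15 h in this assay, within a range from 8 h to 30 h.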

Compound 4, half-life: 1400 h
Compound 4: the middle estimate sits 93-fold (1.97 log units) below what was measured; measured number outside the range, above it.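

In this assay, the same swap of tert-butyl for phenyl on a carbonyl carbon gave a 45-fold higher number from compound 3 to compound 4 (1.65 log units; beyond the scatter), whereas the earlier pair gave a 2.3-fold lower number from compound 1 to compound 2 (0.35 log units; beyond the scatter), so the change moved the number in opposite directions, and by a much larger amount in the new pair. This shows that, in this series, the step seen in one setting cannot simply be carried to another, although two pairs are too few to set a rule, and the swapped group sits on an oxygen in one pair and on a double-bonded ring carbon in the other, so the role of that site cannot be separated from the role of the rest of the core. Nothing available here accounts for the reversal.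

The compounds shown leave open whether the large rise belongs to phenyl itself or would also appear with another group on that carbonyl carbon, such as methyl, a longer chain or an amine. They also leave open what the benzoyl group would do on the core of compound 1.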